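Macrocyclic hydroxamates: aryl to alkyl cap switch

A few compounds are considered here, and "the series" means these few. Any claim that something is new, unique, unknown or untested is made for them only; others in the source may bear on it.

Measured so far:
compound 1 `O=C(NO)c1ccc(NCCOc2ccc3cc2COC/C=C/COCc2cccc(c2)-c2ccnc(n2)N3)cc1` — 395 nM
compound 2 `O=C(NO)c1cccc(NCCOc2ccc3cc2COC/C=C/COCc2cccc(c2)-c2ccnc(n2)N3)c1` — 2900 nM

In an assay on Sf9 cells for inhibition of protein deacetylase HDAC6 (Homo sapiens), read by fluorescence, with a stated time of 2 h (on this read-out higher numbers stand for weaker inhibition and lower numbers for stronger inhibition), compound 2 gives the highest number of the two measured, standing a 7.3-fold higher number from compound 1 to compound 2 (0.87 log units; beyond the scatter) away from compound 1. That single step, the move of the hydroxycarbamoyl group around the phenyl ring, is beyond the scatter and modest in size.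

Compound 3 `O=C(CCCCCOc1ccc2cc1COC/C=C/COCc1cccc(c1)-c1ccnc(n1)N2)NO` is not yet measured. It differs from compound 2 by 3-(hydroxycarbamoyl)propyl in place of (3-(hydroxycarbamoyl)phenyl)amino on a saturated chain carbon, two bonds along the chain from an oxygen on an aromatic ring: the aromatic ring and the amine nitrogen leave, and the hydroxamic acid now sits at the end of a saturated chain. For the measured compounds named here, no measured step bears directly on this change; the only step at hand concerns where the hydroxycarbamoyl group sits on the ring, not its removal from a ring altogether. Because the move from compound 1 to compound 2 was a 7.3-fold higher number from compound 1 to compound 2 (0.87 log units; beyond the scatter), the position of the hydroxamic acid is plainly sensitive, so a step of some size in either direction in this assay is possible. As a working expectation a modest lowering is taken, the estimated step being a 3.2-fold lower number from compound 2 to compound 3 (0.51 log units; beyond the scatter). Compound 3 is therefore estimated at 900 nM in this assay, within 200 nM to 4500 nM.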

Compound 3, half-maximal inhibitory concentration: 28 nM
Compound 3: middle estimate off by 32-fold (1.51 log units), on the high side; measured number outside the range, below it.
By their numbers in this assay, from the lowest: compound 3; then compound 1; then compound 2.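

In this assay, the position two bonds along the chain from the oxygen on the aromatic ring does not depend on the aromatic ring or the amine nitrogen: replacing the (3-(hydroxycarbamoyl)phenyl)amino group with 3-(hydroxycarbamoyl)propyl gives a 100-fold lower number from compound 2 to compound 3 (2.02 log units; beyond the scatter) and replacing the (4-(hydroxycarbamoyl)phenyl)amino group gives a 14-fold lower number from compound 1 to compound 3 (1.15 log units; beyond the scatter) on the same read-out. Compound 3 therefore holds the lowest number of the three, and the switch from an aromatic to a saturated chain outweighs the earlier ring shift of the hydroxycarbamoyl group, a 7.3-fold higher number from compound 1 to compound 2 (0.87 log units; beyond the scatter) in this series. No available evidence accounts for these steps, and the ring and the amine nitrogen leave together, so their separate contributions cannot be told apart.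

Open, from the compounds shown here alone, is how the number responds to chain length at this position, which a shorter or a longer chain ending in the hydroxamic acid would test. Also open, going by these compounds, is whether an amine nitrogen kept within the saturated chain, or a carboxylic acid in place of the hydroxamic acid at its end, is tolerated.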